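Swapping the Sulfonyl Aryl Group of a Hydrazide Series

The compounds below may be only part of what the source reports. "The series", "measured", "known", "first", "only" and "open" are said of these compounds alone.

Measured so far:
compound 1 `CC(=O)Nc1ccc(S(=O)(=O)NNC(=O)c2cccnc2Nc2ccc(Cl)cc2)cc1` gives > 100000 nM in a functional assay on EKVX cells (Homo sapiens) for antiproliferative activity; a lower number here means that less compound is tolerated, a higher number that more compound is tolerated
compound 2 `O=C(NNS(=O)(=O)c1ccc(F)cc1)c1cccnc1Nc1ccc(Cl)cc1Cl` gives > 100000 nM in this assay

Compound 1 stands at a limit: its value of > 100000 nM is the limit of the assay and not a measured number. Compound 2 likewise sits at a limit, reported as > 100000 nM. Among the measured compounds shown here, the two values show only that neither compound reached a measurable concentration, which is summed up by the limit of > 100000 nM in this assay, at which 2 of the 2 values shown sit.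

Compound 3 `O=C(NNS(=O)(=O)c1ccc(Cl)cc1Cl)c1cccnc1Nc1ccc(Cl)cc1` differs from compound 1 in one place: 2,4-dichlorophenyl in place of 4-acetamidophenyl on a sulfonyl sulfur. For the measured compounds named here, no step between two measured compounds is available to size this change. Since both measured compounds sit at the limit, compound 3 is expected to stay there as well, with no step beyond the scatter; the expected step of a number no higher from compound 1 to compound 3 (the limit leaves the size open) is therefore near nothing. Compound 3 is estimated at 100000 nM, within 30000 nM to 300000 nM.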

Compound 3, concentration lethal to 50% of the cells: > 100000 nM
Compound 3 ended at the assay's limit; the forecaster's own chance of this, stated with the estimate: 75%; the middle value lies on the limit itself.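

Compound 1 and compound 3 both stand at a limit and not at a measured number, so no step between them can be read: the limit of > 100000 nM in this assay, at which 3 of the 3 values shown sit.

The compounds shown leave open whether any group on the sulfonyl sulfur would give a measurable value in this assay.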